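Methoxy in Place of Hydrogen on a Short-Lived Compound

This account rests on a few compounds, and the source may have more. Where it says the series, first, only, none or still open, it means among the compounds named here.

For the measured compounds named here, in an ADME assay (on this read-out higher numbers stand for a longer-lived compound and lower numbers for a shorter-lived compound), compound 2 `COc1ccc(C[S+]([O-])c2ncccc2C(=O)Nc2ccncc2)c(OC)c1` gives 0.84 h as the lower of the two numbers so far, while compound 1 `COc1cc(OC)c(C[S+]([O-])c2ncccc2C(=O)Nc2ccncc2)cc1Br` gives 28.8 h on the same read-out. Compound 3 `COc1cc(OC)c(OC)cc1C[S+]([O-])c1ncccc1C(=O)Nc1ccncc1` differs from compound 2 by methoxy in place of hydrogen on an aromatic carbon. The new group stands para to a methoxy group, on the carbon that carries bromo in compound 1. Going by the values given here, the one measured step bearing on this is a 34-fold lower number from compound 1 to compound 2 (1.54 log units; beyond the scatter) at that carbon, a large change beyond the scatter. Bromo is not methoxy, and no measured compound shows methoxy there, so only a modest rise in this assay is expected. The estimated step is a 2.4-fold higher number from compound 2 to compound 3 (0.38 log units; beyond the scatter) in this account. For compound 3 the estimate is 2 h with an expected range from 0.5 h to 10 h for repeated measurements.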

Compound 3, half-life: 0.14 h
Compound 3: the middle estimate sits 14-fold (1.15 log units) above what was measured; the measured number lies below the stated range.
By their numbers in this assay, from the lowest: compound 3; then compound 2; then compound 1.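

In this assay, the carbon that carries bromo in compound 1 now answers in both directions: methoxy in place of hydrogen gives a 6.0-fold lower number from compound 2 to compound 3 (0.78 log units; beyond the scatter), the opposite direction to the rise that bromo shows over hydrogen at that carbon. Methoxy in place of bromo gives a 210-fold lower number from compound 1 to compound 3 (2.31 log units; beyond the scatter), so among these three compounds the number falls from bromo through hydrogen to methoxy, and what matters at this carbon is which group stands there, not merely that one does. No measurement shown here explains this order.

The compounds shown leave open whether the long half-life belongs to bromo alone or would also come with chloro or a methyl group on this carbon. They also leave open whether methoxy here would lower the number on a core lacking the other two methoxy groups.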